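Nitro in Place of Bromo on a Coumarin Hydrazone

A few compounds are considered here, and "the series" means these few. Any claim that something is new, unique, unknown or untested is made for them only; others in the source may bear on it.

Two hydrazones have been measured so far. Compound 1 `CCOc1ccc2nc(Cl)c(/C=N/NC(=O)c3cc4cc(Br)ccc4oc3=O)cc2c1` gives 12900 nM in a functional assay on CCRF-CEM cells (Homo sapiens) for antiproliferative activity, read by fluorescence and resazurin assay, with a stated time of 48 h; a higher number here means a weaker inhibitor, a lower number a stronger inhibitor. Compound 2 `O=C(N/N=C/c1cc2ccccc2nc1Cl)c1cc2cc(Br)ccc2oc1=O` differs from it by hydrogen in place of ethoxy on an aromatic carbon, and in this assay compound 2 gives 7450 nM. The step of a 1.7-fold lower number from compound 1 to compound 2 (0.24 log units; within the scatter) lies within the scatter, so although the number for compound 2 is the smaller of the two shown, compound 2 and compound 1 cannot be told apart on these data.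

Compound 3 `O=C(N/N=C/c1cc2ccccc2nc1Cl)c1cc2cc([N+](=O)[O-])ccc2oc1=O` is the next compound, differing from compound 2 by nitro in place of bromo on an aromatic carbon. Within the data shown here, no measured step touches this position: the only step available, a 1.7-fold lower number from compound 1 to compound 2 (0.24 log units; within the scatter), concerns the ethoxy of compound 1 at the other end of the shared core and was itself within the scatter. With nothing to point either way, the expected step is none beyond the scatter, a 1.0-fold higher number from compound 2 to compound 3 (0.00 log units; within the scatter). Compound 3 is therefore estimated to give about 7500 nM in this assay, with a range from 2500 nM to 22000 nM.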

Compound 3, half-maximal inhibitory concentration: 26000 nM
The estimate for compound 3 lay 3.5-fold (0.54 log units) below the measured number; measured number outside the range, above it.
By their numbers in this assay, from the lowest: compounds 2, 1 and 3 (each within the scatter of the next, the first and the last beyond it).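

Among these compounds, the change from bromo to nitro gives the first step that stands beyond the scatter: in this assay there is a 3.5-fold higher number from compound 2 to compound 3 (0.54 log units; beyond the scatter), a modest but readable difference. The earlier step, at the ethoxy, could not separate its two compounds, whereas this aromatic carbon, meta to a fused ring and para to a fused ring, does respond to the group it carries, with bromo giving the lower number of the two on this shared core. The data offer no measured basis for explaining this difference, which rests on a single pair of compounds.

Going by these compounds, whether an amine, a carboxylic acid or a plain hydrogen on this carbon would give a number closer to that of bromo or to that of nitro remains open. Also open, on these data alone, is whether the ethoxy, whose removal gave a 1.7-fold lower number from compound 1 to compound 2 (0.24 log units; within the scatter), would remain without a readable effect on a core that carries nitro rather than bromo.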